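Swapping a Short Chain Back for a Fluorinated Ring

A few compounds are considered here, and "the series" means these few. Any claim that something is new, unique, unknown or untested is made for them only; others in the source may bear on it.

Measured so far:
- Compound 1, `O=C1CC(c2ccccc2OCc2ccc(F)cc2)Oc2ccccc21`, gives 45.2% in a functional assay on RAW264.7 cells (Mus musculus) for inhibition, read by immunoassay, with a stated time of 12 h, tested at 30 uM; a higher number here means more inhibition at the concentration tested (going by the name of the read-out), a lower number less inhibition.
- Compound 2, `CCCCCOc1ccccc1C1CC(=O)c2ccccc2O1`, gives 41.3% in this assay.

Among the compounds with values here, compound 2 holds the lower of the two numbers, but its only neighbour is compound 1, and the gap of a number 3.9 percentage points lower from compound 1 to compound 2 (within the scatter) sits within the usual scatter of this kind of measurement. On these two values, then, compound 1 and compound 2 cannot be told apart.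

Compound 3, `O=C1CC(c2ccccc2OCc2cccc(F)c2)Oc2ccccc21`, is not yet measured. The change from compound 2 is 3-fluorophenyl in place of butyl on a saturated chain carbon bound to an oxygen on an aromatic ring. Within the data shown here, this is close to the reverse of the one step already seen: there, the move from a fluorophenyl group to butyl gave a number 3.9 percentage points lower from compound 1 to compound 2 (within the scatter), a change inside the scatter. Among the measured compounds shown here, nothing here separates the 3-fluorophenyl group from the 4-fluorophenyl group of compound 1, so the only evidence points to little or no movement.

Compound 3 is therefore expected to give about 44% in this assay, with a range of 30% to 58%, an estimated step of a number 2.7 percentage points higher from compound 2 to compound 3 (within the scatter) that stays within the scatter.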

Compound 3, a percentage reported as inhibition, at one concentration (the size of the read-out at that concentration, not a potency): 93.3%
Estimate against measurement, compound 3: 49.3 percentage points below; measured number above the stated range.
By their numbers in this assay, from the lowest: compounds 2 and 1 (each within the scatter of the next); then compound 3.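

In this assay the position on a saturated chain carbon bound to an oxygen on an aromatic ring proves highly sensitive, and a fluorinated ring alone does not account for the gain. Placing 3-fluorophenyl in place of 4-fluorophenyl gives a number 48.1 percentage points higher from compound 1 to compound 3 (beyond the scatter) even though the two groups hold the same atoms and differ only in where the fluorine stands, while 3-fluorophenyl in place of butyl gives a number 52 percentage points higher from compound 2 to compound 3 (beyond the scatter) and so sets compound 3 apart from both earlier compounds. No measurement shown here explains why moving a single fluorine changes the read-out so much.

On these data alone, what remains open is whether fluorine itself matters or whether another group in the same place on this ring would serve as well, which a plain phenyl, 3-chlorophenyl or 3-methoxyphenyl group could help to show. As far as these compounds go, it is also open how far the ring can change, for instance to a pyridine ring carrying a nitrogen atom, and whether the large gain seen at this single tested concentration would carry over to a full measure of potency.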